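Moving the nitrile around the benzyl ether ring

The source may report more compounds than this note shows. Statements on the series, on what has been measured and on what is new or still open speak of the compounds shown alone.

Measured compounds:
compound 1, `Cc1ccc(COc2ccc(-c3cc(CN4CCN(Cc5ccc(C(F)(F)F)cc5)CC4)no3)cc2)cc1`, 7500 nM
compound 2, `FC(F)(F)c1ccc(CN2CCN(Cc3cc(-c4ccc(OCc5ccccc5Cl)cc4)on3)CC2)cc1`, 3200 nM
compound 3, `N#Cc1ccccc1COc1ccc(-c2cc(CN3CCN(Cc4ccc(C(F)(F)F)cc4)CC3)no2)cc1`, 3500 nM

In a functional assay on Mahlavu cells (Homo sapiens) for antiproliferative activity, read by sulforhodamine B assay, with a stated time of 72 h (a lower number here means a stronger inhibitor, a higher number a weaker inhibitor), compound 3 gives 3500 nM, the second highest of the three numbers. Its nearest neighbour is compound 2, and the gap between them, a 1.1-fold higher number from compound 2 to compound 3 (0.04 log units; within the scatter), lies within the scatter. Compound 1 sits further off: the step of a 2.1-fold lower number from compound 1 to compound 3 (0.33 log units; beyond the scatter) is beyond the scatter, as is the parallel step a 2.3-fold lower number from compound 1 to compound 2 (0.37 log units; beyond the scatter).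

Compound 4, `N#Cc1cccc(COc2ccc(-c3cc(CN4CCN(Cc5ccc(C(F)(F)F)cc5)CC4)no3)cc2)c1`, has not yet been measured. It differs from compound 3 in one place: 3-cyanophenyl in place of 2-cyanophenyl on a saturated chain carbon bound to an oxygen on an aromatic ring. Within the data shown here, no measured step moves a substituent from one position to another on this ring; the two steps that touch this part of the molecule replace 4-methylphenyl with a 2-substituted phenyl, and the exchange of chloro for cyano in the step of a 1.1-fold higher number from compound 2 to compound 3 (0.04 log units; within the scatter) stayed within the scatter. The available steps therefore give no reason to expect a step beyond the scatter in this assay in either direction. Compound 4 is accordingly estimated at 3500 nM, with a range from 1500 nM to 8000 nM. The expected step from compound 3 is no change at the digits printed from compound 3 to compound 4 (within the scatter).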

Compound 4, half-maximal inhibitory concentration: 10600 nM
Estimate against measurement, compound 4: 3.0-fold (0.48 log units) below; the measured number lies above the stated range.
By their numbers in this assay, from the lowest: compounds 2 and 3 (each within the scatter of the next); then compounds 1 and 4 (each within the scatter of the next).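

In this assay, among these compounds, the place of the nitrile on the ring matters: with the substituent unchanged, going from 2-cyanophenyl to 3-cyanophenyl gives a 3.0-fold higher number from compound 3 to compound 4 (0.48 log units; beyond the scatter) and is the first measured step of this kind, while 3-cyanophenyl against 2-chlorophenyl gives a 3.3-fold higher number from compound 2 to compound 4 (0.52 log units; beyond the scatter) as well. Against 4-methylphenyl, 3-cyanophenyl gives a 1.4-fold higher number from compound 1 to compound 4 (0.15 log units; within the scatter) so the lower numbers seen with 2-chlorophenyl and 2-cyanophenyl are not shared by this isomer, and the nitrile alone does not set the number. Nothing available explains why the place of the nitrile changes the result.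

On these data alone, whether chloro responds to the same move on the ring as the nitrile does remains open. So does what a carboxylic acid or a methoxy group would give in place of the nitrile.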